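A few compounds are considered here, and "the series" means these few. Any claim that something is new, unique, unknown or untested is made for them only; others in the source may bear on it.

Series notes. The shared core of compound 1 `COc1cc(-c2nnc(SCC(=O)c3ccc(Br)cc3)n2N)cc(OC)c1OC` carries a 4-bromophenyl group on a carbonyl carbon. In a functional assay on PC-3 cells (Homo sapiens) for antiproliferative activity, read by MTT assay, with a stated time of 48 h (a higher number here means a weaker inhibitor, a lower number a stronger inhibitor), compound 1 returns only a limit, > 100000 nM, and no number. Compound 2 `COc1cc(-c2nnc(SCC(=O)c3ccc(F)cc3)n2N)cc(OC)c1OC` likewise returns only a limit in this assay, > 100000 nM. Compound 3 `COc1cccc(NC(=O)CSc2nnc(-c3cc(OC)c(OC)c(OC)c3)n2N)c1`, the amide of the set, again gives only a limit in this assay, > 100000 nM. The steps a step that the two limits leave unreadable from compound 1 to compound 2, a step that the two limits leave unreadable from compound 1 to compound 3 and a step that the two limits leave unreadable from compound 2 to compound 3 therefore stay unreadable, since (the limit of > 100000 nM in this assay, at which 3 of the 3 values shown sit).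

Compound 4 `COc1cc(-c2nnc(SCC(=O)NCc3ccc(C)cc3)n2N)cc(OC)c1OC` is the next member: (4-methylbenzyl)amino in place of 4-bromophenyl on a carbonyl carbon. The step that bears most directly on this change is a step that the two limits leave unreadable from compound 1 to compound 3, the other replacement at the same carbonyl carbon that turns the ketone into an amide, and it carries no readable size either. With three limits and no readable step, no direction beyond the scatter can be set for compound 4 in this assay. The expectation is that compound 4 again sits at the limit of this assay, with an estimated value of 100000 nM in the range 30000 nM to 300000 nM. The expected step of a number no higher from compound 1 to compound 4 (the limit leaves the size open) is nominal only and carries no information beyond the limit.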

Compound 4, half-maximal inhibitory concentration: 92800 nM
For compound 4 the middle estimate is 1.1-fold (0.03 log units) above the measured one, and the stated range covers the measured number.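

Within the data shown here, at the carbonyl carbon, (4-methylbenzyl)amino gives the first readable number of the series in this assay, where compound 4 returns 92800 nM. The change reads as an at least 1.0-fold lower number from compound 1 to compound 4 (0.03 log units; that floor lies within the scatter), as an at least 1.0-fold lower number from compound 2 to compound 4 (0.03 log units; that floor lies within the scatter) and, on the amide-type nitrogen, as an at least 1.0-fold lower number from compound 3 to compound 4 (0.03 log units; that floor lies within the scatter). Each of these is only a floor, so the series gains a number but shows no change beyond the scatter, and the steps among the other compounds stay unreadable: the limit of > 100000 nM in this assay, at which 3 of the 4 values shown sit.

From the compounds shown here alone, how a carboxylic acid at this carbonyl carbon, or a longer chain on the amide-type nitrogen, would read in this assay stays open. Going by these compounds, the shared core is the same in all four compounds, so what a change there would do also stays open.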